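Arginine-type side chain on the chlorinated core

The source may hold more compounds than are shown below. What is called first, only, known or untested is meant among the compounds shown, and "the series" means these compounds.

Three compounds of the series have numbers in a functional assay on the whole organism (Tail, strain ICR) with Mus musculus as the target, in the tail flick test, with a stated time of 90 min, at a dose of 25 umol/kg by the oral route; on this read-out higher numbers stand for a stronger effect at the one dose given and lower numbers for a weaker effect. Compound 1 `O=C(O)[C@@H]1CCCN1C(=O)CN(c1nc(Cl)nc2[nH]cnc12)C1CC1` gives 26%. Compound 2 `N=C(N)NCCC[C@H](NC(=O)CN(c1ncnc2c1ncn2C1CCCCO1)C1CC1)C(=O)OCc1ccccc1` gives 61.6%. Compound 3 `CSCC[C@H](NC(=O)CN(c1nc(Cl)nc2[nH]cnc12)C1CC1)C(=O)OCc1ccccc1` gives 44.6%, the second highest of the three: compound 2 stands higher and compound 1 lower, both by gaps beyond the usual scatter. Among the compounds with values here, compound 2 and compound 3 share the same pairing of an ester chain with the cyclopropyl-bearing glycinamide, but differ in the core as well as in the side chain, so no single step between them can be isolated.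

Compound 4 `N=C(N)NCCC[C@H](NC(=O)CN(c1nc(Cl)nc2[nH]cnc12)C1CC1)C(=O)OCc1ccccc1` is not yet measured. It differs from compound 3 in one place: a group of 5 heavy atoms (2 carbon, 3 nitrogen; no ring) in place of a group of 2 heavy atoms (1 carbon, 1 sulfur; no ring), on a saturated chain carbon, three bonds along the chain from an amide-type nitrogen and a carbonyl carbon. Within the data shown here, the side chain that enters is the one already carried by compound 2, while the core of compound 4 is that of compound 3.

The step of a number 12.4 percentage points higher from compound 3 to compound 4 (beyond the scatter) is expected to be upward and beyond the scatter, because compound 2, which carries the same chain, gives 61.6%. Compound 4 is therefore estimated at 57%, within 42% to 72%.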

Compound 4, a percentage reported as activity, at one dose (the size of the read-out at that dose, not a potency): 30.4%
The estimate for compound 4 lay 26.6 percentage points above the measured number; measured number below the stated range.
By their numbers in this assay, from the lowest: compounds 1 and 4 (each within the scatter of the next); then compound 3; then compound 2.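

Within the data shown here, on the shared core, this assay gives the first readable step at this position: a number 14.2 percentage points lower from compound 3 to compound 4 (beyond the scatter), as methylsulfanyl leaves and the group of 5 heavy atoms enters on the saturated chain carbon. Among these compounds, the position therefore responds to this change, and on this core the entering group goes with the lower number, a direction that the earlier compounds, with no step between them, could not show. No measured evidence bears on the reason for this step.

Still open, as far as these compounds go, is whether a chain ending in a simple amine or a carboxylic acid at this place would track with methylsulfanyl or with the entering group. From the compounds shown here alone, it is also open whether methylsulfanyl on the core of compound 2 would show a step of the same direction, so this one step cannot be generalised across cores.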